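The source may report more compounds than this note shows. Statements on the series, on what has been measured and on what is new or still open speak of the compounds shown alone.

Compound 1 `N#CC1=C(N)Oc2c(c3nc4ccccc4nc3c3ccccc23)C12C(=O)N(Cc1cnnn1-c1cccc(S(N)(=O)=O)c1)c1ccccc12` and compound 2 `N#CC1=C(N)Oc2c(c3nc4ccccc4nc3c3ccccc23)C12C(=O)N(Cc1cnnn1-c1cc(Cl)ccc1Cl)c1ccccc12` share the core of the series with compound 3 and differ only in the group on the aromatic nitrogen. In an ADME assay on L02 cells (Homo sapiens) for antiproliferative activity, read by MTT assay, with a stated time of 48 h (a lower number here means a stronger inhibitor, a higher number a weaker inhibitor), compound 1 gives > 50000 nM, which is a limit of the assay and not a number. In this assay compound 2 gives > 50000 nM, again a limit. The step that the two limits leave unreadable from compound 1 to compound 2 is therefore unreadable. Among the compounds with values here, compound 3 `N#CC1=C(N)Oc2c(N)cc3nc4ccccc4nc3c2C12C(=O)N(Cc1cnnn1-c1ccccc1Br)c1ccccc12` carries the only number in the set: in this assay compound 3 gives 29200 nM, while the two further values sit at the limit of > 50000 nM in this assay, at which 2 of the 3 values shown sit.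

Compound 4 `Cc1ccc(-n2nncc2CN2C(=O)C3(C(C#N)=C(N)Oc4c(N)cc5nc6ccccc6nc5c43)c3ccccc32)cc1Cl` differs from compound 3 by 3-chloro-4-methylphenyl in place of 2-bromophenyl on an aromatic nitrogen. No measured step bears on this change, since the one step shown, from compound 1 to compound 2, is unreadable, and the two groups match in the counted donors, acceptors and charge. The expectation is therefore a step of a 1.0-fold higher number from compound 3 to compound 4 (0.01 log units; within the scatter), no larger than the scatter. For compound 4 in this assay the estimated value is 30000 nM, expected to fall between 12000 nM and 75000 nM.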

Compound 4, half-maximal inhibitory concentration: > 50000 nM
Compound 4 gave a limit, no number (the forecaster's own chance of this, stated with the estimate: 35%); at least 1.6-fold (0.22 log units) between middle value and limit.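

In this assay compound 4 gives > 50000 nM, a limit of the assay and not a number. Within the data shown here, with 3-chloro-4-methylphenyl in place of 2-bromophenyl on the aromatic nitrogen, the result is an at least 1.7-fold higher number from compound 3 to compound 4 (0.23 log units; that floor lies within the scatter); this is the first step at this position with any readable size, but it is only a floor and does not by itself clear the scatter. Compound 3 remains the only compound with a number, and the set now sits mostly at one value: the limit of > 50000 nM in this assay, at which 3 of the 4 values shown sit.

On these data alone, how far compound 4 lies past the limit stays open, and so does the true size of this step. Also open, as far as these compounds go, is whether a phenyl carrying an amine or a carboxylic acid, or a plain alkyl chain, on this nitrogen of the core of compound 3 would give a number.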